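Aryl variation on the shared core: outlook for compound 3

A few compounds are considered here, and "the series" means these few. Any claim that something is new, unique, unknown or untested is made for them only; others in the source may bear on it.

Measured so far:
compound 1 `CCCCCCCCCCCCCCCCCCNC(=O)[C@H]1CSC(CCCCCCCCCCCC)N1`, 15000 nM
compound 2 `CCCCCCCCCCCCCCCCCCNC(=O)[C@H]1CSC(c2ccc(N(C)C)cc2)N1`, 6000 nM

In a functional assay on PC-3 cells (Homo sapiens) for antiproliferative activity, read by sulforhodamine B assay (a higher number here means a weaker inhibitor, a lower number a stronger inhibitor), compound 1 gives 15000 nM. Compound 2 gives 6000 nM in this assay. Among the measured compounds shown here, the one step measured, a 2.5-fold lower number from compound 1 to compound 2 (0.40 log units; beyond the scatter), puts the 4-(dimethylamino)phenyl compound 2 at the lowest of the two numbers, with compound 1 as its only neighbour.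

Compound 3 `CCCCCCCCCCCCCCCCCCNC(=O)[C@H]1CSC(c2cccc(O)c2)N1` has not yet been measured in this assay. It differs from compound 2 in one place: 3-hydroxyphenyl in place of 4-(dimethylamino)phenyl on a saturated ring carbon. For the measured compounds named here, no measured step compares one aryl group with another on that saturated ring carbon; the only step known, from compound 1 to compound 2, exchanges a dodecyl chain for an aryl group and is therefore of limited bearing on this swap. Both compound 2 and compound 3 carry a six-membered aromatic ring at that position, so compound 3 is expected to stay close to compound 2, with a step of a 1.2-fold higher number from compound 2 to compound 3 (0.07 log units; within the scatter) that does not clearly exceed the scatter. For compound 3 in this assay the estimate is 7000 nM, within a range from 2500 nM to 20000 nM.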

Compound 3, half-maximal inhibitory concentration: 6700 nM
Compound 3: the middle estimate sits 1.0-fold (0.02 log units) above what was measured; low and high end bracket the measured number.
By their numbers in this assay, from the lowest: compounds 2 and 3 (each within the scatter of the next); then compound 1.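

In this assay, among the compounds shown here, the first exchange of one aryl group for another on this saturated ring carbon gives a 1.1-fold higher number from compound 2 to compound 3 (0.05 log units; within the scatter) and so does not separate 3-hydroxyphenyl from 4-(dimethylamino)phenyl, even though only 3-hydroxyphenyl carries a hydrogen-bond donor. Replacing dodecyl with 3-hydroxyphenyl gives a 2.2-fold lower number from compound 1 to compound 3 (0.35 log units; beyond the scatter) and is a modest step beyond the scatter, so the gain over dodecyl at this position is now seen with two different aryl groups rather than with 4-(dimethylamino)phenyl alone. No supporting data are available to account for either step.

Still open, from the compounds shown here alone, is whether the aryl groups at this position can be told apart at all, as an unsubstituted phenyl, a 4-hydroxyphenyl or a 4-carboxyphenyl could show whether the substituent or its place on the ring has any bearing on the read-out. Going by these compounds, it is also open whether the difference from compound 1 depends on the aromatic ring itself, which a cyclohexyl group or a shorter chain such as hexyl on the same carbon would help to settle.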